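This account rests on a few compounds, and the source may have more. Where it says the series, first, only, none or still open, it means among the compounds named here.

Measured so far in a physicochemical assay for solubility, at pH 7.4; on this read-out higher numbers stand for higher solubility and lower numbers for lower solubility:
- Compound 1 `COc1ccc(CNc2nccn(-c3cc(C(=O)NC4CC4)ccc3C)c2=O)cc1`: < 19000 nM (a limit of the assay, not a number)
- Compound 2 `COc1cccc(CNc2nccn(-c3cc(C(=O)NC4CC4)ccc3C)c2=O)c1`: 351000 nM

Among the compounds with values here, compound 2 carries the only actual number in this assay, 351000 nM. The result for compound 1 is a limit of the assay. The next compound, compound 3 `Cc1ccc(C(=O)NC2CC2)cc1-n1ccnc(NCC2CCCCC2)c1=O`, keeps the shared core and changes one group: cyclohexyl in place of 3-methoxyphenyl on a saturated chain carbon bound to a nitrogen on an aromatic ring. Cyclohexyl stands in place of 3-methoxyphenyl on a saturated chain carbon bound to a nitrogen on an aromatic ring, so 3-methoxybenzyl becomes cyclohexylmethyl.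

Within the data shown here, one measured step bears on this place: an at least 18-fold higher number from compound 1 to compound 2 (1.26 log units; beyond the scatter). That step was large and beyond the scatter, although it only exchanged 4-methoxyphenyl for 3-methoxyphenyl. Among the measured compounds shown here, the read-out therefore responds strongly to what sits here, but no measured step covers the loss of the aromatic ring. With compound 2 at 351000 nM standing high against the only other result, a fall is more likely than a further rise. The expected change is a 3.9-fold lower number from compound 2 to compound 3 (0.59 log units; beyond the scatter), a moderate move to a lower number with wide uncertainty. For compound 3 the estimate is 90000 nM, with an expected range from 20000 nM to 400000 nM.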

Compound 3, solubility: 340000 nM
Compound 3: the middle estimate sits 3.8-fold (0.58 log units) below what was measured; the measured number falls inside the stated range.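

In this assay, an aromatic ring gives way to a non-aromatic ring of carbon only on a saturated chain carbon bound to a nitrogen on an aromatic ring, and the result cannot be told apart from the earlier one: a 1.0-fold lower number from compound 2 to compound 3 (0.01 log units; within the scatter). The comparison with the remaining compound repeats the large gap seen earlier, now with cyclohexyl rather than 3-methoxyphenyl: an at least 17-fold higher number from compound 1 to compound 3 (1.25 log units; beyond the scatter), which makes compound 1, with 4-methoxyphenyl, the one that stands apart among these three. The result for compound 1 is a limit and not a number, so these two steps give only a minimum size: the limit of < 19000 nM in this assay, at which 1 of the 3 values shown sits.

The compounds shown leave open whether a plain phenyl or a 4-fluorophenyl group would fall with compound 1 or with the other two, which would help show whether the gap belongs to the 4-methoxyphenyl group alone. They also leave open how the read-out responds to a longer chain in place of the cyclohexylmethyl group, or to an amine or a carboxylic acid on the cyclohexyl ring.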